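Macrophage tolerance of two measured analogues and one pending

The source may report more compounds than this note shows. Statements on the series, on what has been measured and on what is new or still open speak of the compounds shown alone.

Measured so far:
compound 1, `CC1(c2ccc(-c3ccccc3C#N)cc2)CC(S(=O)(=O)c2ccc(F)cc2)=C(c2ccc(/C(N)=N\O)cc2)O1`: 9290 nM
compound 2, `CCC1(c2ccccc2OC)CC(S(=O)(=O)c2ccc(F)cc2)=C(c2ccc(/C(N)=N\O)cc2)O1`: 9880 nM

In an ADME assay on J774.A1 cells (Mus musculus) for cytotoxicity, read by MTT assay, with a stated time of 72 h (a lower number here means that less compound is tolerated, a higher number that more compound is tolerated), compound 1 gives 9290 nM and compound 2 gives 9880 nM. Compound 1 has the lower of the two numbers, but its gap to compound 2 lies within the scatter, so no order between them is claimed. Compound 3, `CC1(c2ccc(-c3ccncc3)cc2)CC(S(=O)(=O)c2ccc(F)cc2)=C(c2ccc(/C(N)=N\O)cc2)O1`, is not yet measured. Relative to compound 1 the change is pyridin-4-yl in place of 2-cyanophenyl on an aromatic carbon. Among the compounds with values here, no step between measured compounds bears on this change, so nothing beyond the scatter is expected in either direction. Compound 3 is expected to give 9500 nM, in the range 4500 nM to 20000 nM. The implied step a 1.0-fold higher number from compound 1 to compound 3 (0.01 log units; within the scatter) is expected to stay within the scatter.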

Compound 3, half-maximal cytotoxic concentration: 6750 nM
Beside the measured number, compound 3's estimate is 1.4-fold (0.15 log units) above it, and the stated range covers the measured number.
By their numbers in this assay, from the lowest: compounds 3, 1 and 2 (each within the scatter of the next).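

In this assay, this position now has its first step, a 1.4-fold lower number from compound 1 to compound 3 (0.14 log units; within the scatter), and it lies within the scatter. Pyridin-4-yl and 2-cyanophenyl, on an aromatic carbon para to a large group, are therefore not separated here, even though the nitrile is lost and the ring gains a hetero atom. No measured property bears on this result.

Still open, going by these compounds, is whether a non-aromatic group at this position, such as an amine or a carboxylic acid, would give a step beyond the scatter. The compounds shown also leave open whether pyridin-3-yl would behave like pyridin-4-yl.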